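This account rests on a few compounds, and the source may have more. Where it says the series, first, only, none or still open, it means among the compounds named here.

Compound 1 `Cc1ccc(/C=C(/C#N)C(=O)c2ccc[nH]2)cc1` - < 10000 nM
Compound 2 `N#C/C(=C/c1ccc([N+](=O)[O-])cc1)C(=O)c1ccc[nH]1` - < 10000 nM
Compound 3 `N#C/C(=C/c1ccc(Cl)c(Cl)c1)C(=O)c1ccc[nH]1` - < 10000 nM

All three entries come from a functional assay on A-431 cells (Homo sapiens) for cytotoxicity, read by MTT assay, with a stated time of 72 h (on this read-out lower numbers stand for stronger inhibition of growth and higher numbers for weaker inhibition of growth), and each is a limit, not a number. Compound 2 stands only at its limit of < 10000 nM and has no exact value. The shared position is the limit of < 10000 nM in this assay, at which 3 of the 3 values shown sit, and gives no ranking among the three.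

The change to compound 4 `COc1ccc(/C=C(/C#N)C(=O)c2ccc[nH]2)cc1` is methoxy in place of nitro on an aromatic carbon. Within the data shown here, the one measured step that touches the nitro group (a step that the two limits leave unreadable from compound 1 to compound 2) offers no size or direction to carry over. No step beyond the scatter is therefore expected (a step that the limit leaves unreadable from compound 2 to compound 4). For compound 4 the estimated value is 5000 nM (expected range 1000 nM to 10000 nM) in this assay and it may also be reported only as a limit.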

Compound 4, concentration for 50% growth inhibition: 13000 nM
Estimate against measurement, compound 4: 2.6-fold (0.41 log units) below, outside the stated range (above it).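

Among these compounds, compound 4 gives 13000 nM in this assay, the first exact number for a group at this place, para to a large group. Methoxy in place of nitro gives an at least 1.3-fold higher number from compound 2 to compound 4 (0.11 log units; that floor lies within the scatter), and methoxy in place of methyl gives an at least 1.3-fold higher number from compound 1 to compound 4 (0.11 log units; that floor lies within the scatter), so neither change is shown to go beyond the scatter. The other three compounds remain limits, not numbers: the limit of < 10000 nM in this assay, at which 3 of the 4 values shown sit.

Going by these compounds, the true size of both steps stays open. So does what an amine or a carboxylic acid at this same place would do to the number.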